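Working notes: replacing the formyl group of compound 3

The source may report more compounds than this note shows. Statements on the series, on what has been measured and on what is new or still open speak of the compounds shown alone.

Measured in an ADME assay on cells (Peritoneal macrophage, Mus musculus, strain BALB/c) for cytotoxicity, read by fluorescence and resazurin assay, with a stated time of 72 h; on this read-out higher numbers stand for lower toxicity in this test and lower numbers for higher toxicity in this test:
- compound 1 `C/[N+]([O-])=C\c1ccc([N+](=O)[O-])cc1`: > 100000 nM
- compound 2 `O=[N+]([O-])c1ccc(/C=[N+](\[O-])Cc2ccccc2)o1`: 31900 nM
- compound 3 `O=Cc1ccc([N+](=O)[O-])s1`: 6250 nM

The entry for compound 1, > 100000 nM, is a limit and not a number. Compound 3 gives 6250 nM, the lowest number of the set. Compound 2 stands higher at 31900 nM, a gap beyond the usual scatter.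

Compound 4 `C/[N+]([O-])=C/c1ccc([N+](=O)[O-])s1` remains to be measured. Relative to compound 3, the change is a group of 4 heavy atoms (2 carbon, 1 nitrogen, 1 oxygen; no ring) in place of a group of 2 heavy atoms (1 carbon, 1 oxygen; no ring), on an aromatic carbon. The formyl leaves an aromatic carbon of a five-membered aromatic ring with 1 sulfur, next to the ring sulfur, and a group with no common name enters there.

Within the data shown here, no measured pair in the set differs in one place, so the expectation rests on thin ground. Compound 2, which has no formyl, reads 31900 nM, and on that basis a rise beyond the scatter is expected in this assay, towards lower toxicity in this test. The expected step is a 3.2-fold higher number from compound 3 to compound 4 (0.51 log units; beyond the scatter). Compound 4 is estimated at 20000 nM, with an expected range of 6000 nM to 70000 nM.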

Compound 4, half-maximal cytotoxic concentration: 24200 nM
The estimate for compound 4 lay 1.2-fold (0.08 log units) below the measured number; the measured number falls inside the stated range.
By their numbers in this assay, from the lowest: compound 3; then compounds 4 and 2 (each within the scatter of the next). At a limit, above all of these: compound 1.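

Among these compounds, replacing the formyl with the larger group of compound 4 gives the first reading of a single change: in this assay there is a 3.9-fold higher number from compound 3 to compound 4 (0.59 log units; beyond the scatter). This aromatic carbon, next to the ring sulfur, is therefore a place where changing the substituent moves the read-out, here towards lower toxicity in this test, while the nitro group stays on the ring. The measurements on hand give no cause for this step.

Going by these compounds, whether the rise follows from the nitrogen and oxygen of the new group or from its extra carbon stays open, as does whether a carboxylic acid, an amine or a longer chain on this carbon would move the read-out the same way. Compound 1 and compound 2 differ from compound 4 in more than one place, so they cannot show whether the same replacement would hold on another core.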